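Adding a nitro group to compound 1

The source may report more compounds than this note shows. Statements on the series, on what has been measured and on what is new or still open speak of the compounds shown alone.

- compound 1 `CCn1cc(-c2nc3ccccc3o2)c(=O)c2cc(F)c(N3CCNCC3)nc21`: 16800 nM
- compound 2 `CCn1cc(-c2nc3ccccc3s2)c(=O)c2cc(F)c(N3CCNCC3)nc21`: 2400 nM
- compound 3 `CCn1cc(-c2nc3ccc(Cl)cc3[nH]2)c(=O)c2cc(F)c(N3CCNCC3)nc21`: 21500 nM

In a functional assay on Bel-7402 cells (Homo sapiens) for cytotoxicity, read by MTT assay, with a stated time of 48 h (on this read-out higher numbers stand for weaker inhibition and lower numbers for stronger inhibition), compound 1 stands at the high end of these three numbers. The nearest neighbour is a 1.3-fold higher number from compound 1 to compound 3 (0.11 log units; within the scatter), and the furthest is a 7.0-fold lower number from compound 1 to compound 2 (0.85 log units; beyond the scatter).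

Compound 4 `CCn1cc(-c2nc3ccc([N+](=O)[O-])cc3o2)c(=O)c2cc(F)c(N3CCNCC3)nc21` changes the core of compound 1 in one place: nitro in place of hydrogen on an aromatic carbon. Within the data shown here, no measured step adds nitro, so the guides are indirect. Swapping in the 6-chloro-1H-benzimidazol-2-yl group gave a 1.3-fold higher number from compound 1 to compound 3 (0.11 log units; within the scatter), while swapping in the 1,3-benzothiazol-2-yl group gave a 7.0-fold lower number from compound 1 to compound 2 (0.85 log units; beyond the scatter). Neither step settles the direction, so no clear change is expected. The expected step is a 1.4-fold lower number from compound 1 to compound 4 (0.15 log units; within the scatter). The estimate for compound 4 is 12000 nM, with a range from 3500 nM to 40000 nM.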

Compound 4, half-maximal inhibitory concentration: 3000 nM
Estimate against measurement, compound 4: 4.0-fold (0.60 log units) above, and the stated range ends above it.
By their numbers in this assay, from the lowest: compounds 2 and 4 (each within the scatter of the next); then compounds 1 and 3 (each within the scatter of the next).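

In this assay, nitro in place of hydrogen gives a 5.6-fold lower number from compound 1 to compound 4 (0.75 log units; beyond the scatter), so this aromatic carbon of the fused system can change the number. The earlier steps shown here each swapped a whole fused group, whereas this one shows that a single addition to the six-membered carbon ring, with the rest of compound 1 held fixed, moves the number beyond the scatter. No measurement here gives a reason for the shift.

Open, from the compounds shown here alone, is whether the shift belongs to nitro itself or would also come with an amine or a methoxy group on this same carbon.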